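The source may hold more compounds than are shown below. What is called first, only, known or untested is meant among the compounds shown, and "the series" means these compounds.

Compound 1, `Fc1cccc(F)c1Cn1ccc2nc(-c3ccccc3)nc-2c1`, gives > 100000 nM in an ADME assay on MDBK cells (Bos taurus) for cytotoxicity (a higher number here means that more compound is tolerated, a lower number that less compound is tolerated), which is a limit of the assay and not a number.
Compound 2, `c1ccc(Cn2ccc3nc(-c4ccccc4)nc-3c2)cc1`, gives > 100000 nM in this assay, again a limit rather than a number.
Compound 3, `Brc1ccc(Cn2ccc3nc(-c4ccccc4)nc-3c2)cc1`, gives 83000 nM in this assay.

For the measured compounds named here, compound 3 thus holds the only real number among the three values; the other two sit at a limit, as the limit of > 100000 nM in this assay, at which 2 of the 3 values shown sit, records. The not yet measured compound 4, `c1ccc(-c2nc3ccn(Cc4ccccn4)cc-3n2)cc1`, differs from compound 3 in one place: pyridin-2-yl in place of 4-bromophenyl on a saturated chain carbon bound to an aromatic nitrogen. Two measured steps end at compound 3 and touch the same position: an at least 1.2-fold lower number from compound 1 to compound 3 (0.08 log units; that floor lies within the scatter) and an at least 1.2-fold lower number from compound 2 to compound 3 (0.08 log units; that floor lies within the scatter), both only a floor that lies within the scatter. The step that the two limits leave unreadable from compound 1 to compound 2 gives no readable size. Since compound 4 again carries no bromine, a small move back toward the limit, or no step beyond the scatter, is expected: a 1.4-fold higher number from compound 3 to compound 4 (0.16 log units; within the scatter). Compound 4 is therefore estimated at 120000 nM, with a likely range from 60000 nM to 300000 nM.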

Compound 4, half-maximal cytotoxic concentration: > 100000 nM
Compound 4: no number, only a limit; the forecaster's own chance of this, stated with the estimate: 60%; the middle value lies beyond the limit too.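

Pyridin-2-yl brings a ring with a hetero atom to this place, on a saturated chain carbon bound to an aromatic nitrogen, and in this assay compound 4 still gives only a limit and not a number. For the compounds shown here, measured against the one real number in the set, pyridin-2-yl in place of 4-bromophenyl gives an at least 1.2-fold higher number from compound 3 to compound 4 (0.08 log units; that floor lies within the scatter), while the steps from compound 1 and from compound 2 to compound 4 cannot be read, with limits at both ends. Pyridin-2-yl thus joins phenyl and 2,6-difluorophenyl at the same limit: the limit of > 100000 nM in this assay, at which 3 of the 4 values shown sit.

Going by these compounds, how far beyond its limit compound 4 truly lies stays open, so the real size of its step from compound 3 is unknown. Also open, on these data alone, is whether an amine or a carboxylic acid in this place would lower the number in this assay.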